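Side-chain ring swap on the shared core

The compounds below may be only part of what the source reports. "The series", "measured", "known", "first", "only" and "open" are said of these compounds alone.

Among the measured compounds shown here, compound 1 `C[C@@]1(O)CC(=O)OC(CSc2nc(-c3ccccc3)c(-c3ccccc3)[nH]2)C1` stands lowest of the two numbers so far in an assay on microsomes from liver for inhibition of sterol O-acyltransferase 1 (Rattus norvegicus) (a higher number here means a weaker inhibitor, a lower number a stronger inhibitor), with 170 nM. For the measured compounds named here, compound 2 `Cn1c(SC[C@H]2C[C@@](C)(O)CC(=O)O2)nc(-c2ccccc2)c1-c1ccccc1.Cn1c(SC[C@H]2C[C@](C)(O)CC(=O)O2)nc(-c2ccccc2)c1-c1ccccc1` gives 2600 nM in this assay, a higher number well beyond the scatter; no single-place step links these two. Compound 3 `O=C1CCC(CSc2nc(-c3ccccc3)c(-c3ccccc3)[nH]2)N1` differs from compound 1 by a group of 6 heavy atoms (4 carbon, 1 nitrogen, 1 oxygen; one five-membered non-aromatic ring with 1 hetero atom) in place of a group of 9 heavy atoms (6 carbon, 3 oxygen; one six-membered non-aromatic ring with 1 hetero atom), on a saturated chain carbon bound to a sulfur. Going by the values given here, no measured pair of this kind exists, so the size of the step is open; a modest loss in this assay is expected, a 2.9-fold higher number from compound 1 to compound 3 (0.47 log units; beyond the scatter). Compound 3 is estimated at 500 nM, with a range from 120 nM to 2500 nM.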

Compound 3, half-maximal inhibitory concentration: 360 nM
Compound 3: the middle estimate sits 1.4-fold (0.14 log units) above what was measured; the range from low to high includes it.
By their numbers in this assay, from the lowest: compound 1; then compound 3; then compound 2.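

In this assay, the step of a 2.1-fold higher number from compound 1 to compound 3 (0.33 log units; beyond the scatter) is modest, on a saturated chain carbon bound to a sulfur. This place therefore accepts the 5-oxopyrrolidin-2-yl group, a five-membered non-aromatic ring with 1 hydrogen-bond acceptor, in place of the larger six-membered ring with 3 hydrogen-bond acceptors, with only a modest rise in the number. No measurement available here accounts for the size of this step.

On these data alone, whether an amine, a carboxylic acid or a longer chain at this place would give a lower number than either ring remains open.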